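The source may hold more compounds than are shown below. What is called first, only, known or untested is meant among the compounds shown, and "the series" means these compounds.

Measured so far in a functional assay on MGC-803 cells (Homo sapiens) for inhibition, read by sulforhodamine B assay; on this read-out higher numbers stand for weaker inhibition and lower numbers for stronger inhibition:
compound 1 `CCCc1ccc(NC2=CC(=O)c3c(nc4n3[C@H]3OC[C@@H](O)[C@H]3OC4)C2=O)cc1` — 1920 nM
compound 2 `O=C1C(NC2CCCCC2)=CC(=O)c2c1nc1n2[C@H]2OC[C@@H](O)[C@H]2OC1` — > 8000 nM

In this assay compound 1 gives 1920 nM. For compound 2 this assay reports only a limit of the assay, > 8000 nM; compound 2 stands at the limit of > 8000 nM in this assay, at which 1 of the 2 values shown sits. Among the measured compounds shown here, the one measured step, an at least 4.1-fold higher number from compound 1 to compound 2 (0.61 log units; beyond the scatter), concerns the group on the amine nitrogen.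

Compound 3 `O=C1C(N2CCC2)=CC(=O)c2c1nc1n2[C@H]2OC[C@@H](O)[C@H]2OC1` differs from compound 2 by azetidin-1-yl in place of cyclohexylamino on a double-bonded ring carbon. For the measured compounds named here, no measured step changes the amine itself or its ring size, so the measured step bears only loosely here. Compound 3 is expected at 12000 nM (range 4000 nM to 40000 nM). The step that the limit leaves unreadable from compound 2 to compound 3 is expected to stay within the scatter, with the limit likely again.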

Compound 3, half-maximal inhibitory concentration: > 16000 nM
Compound 3: only a limit was reported (the forecaster's own chance of this, stated with the estimate: 70%); at least 1.3-fold (0.12 log units) between middle value and limit.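

Compound 2, at > 8000 nM, stands only at a limit of the assay. Among the compounds shown here, compound 3, at > 16000 nM, is also only a limit, so no step between them can be read. The compounds shown leave open whether cyclohexylamino and azetidin-1-yl differ at all.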